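Adding benzyloxy to compound 1: a permeability estimate

The source may hold more compounds than are shown below. What is called first, only, known or untested is meant among the compounds shown, and "the series" means these compounds.

- compound 1 `Cc1nc2cc(-c3ccccc3)nn2c(N2CCC(C)(C)CC2)c1C(OC(C)(C)C)C(=O)O` gives 703 nm/s
- compound 2 `Cc1nc2cc(-c3ccc(OCc4ccccc4)cc3)nn2c(-c2cc(F)c3c(c2C)CCCO3)c1C(OC(C)(C)C)C(=O)O` gives 313 nm/s
- compound 3 `Cc1nc2cc(-c3cccc(-c4ccccc4)c3)nn2c(-c2cc(F)c3c(c2C)CCCO3)c1[C@H](OC(C)(C)C)C(=O)O` gives 733 nm/s

These three compounds were measured in an ADME assay for permeability, using PAMPA, with a stated time of 4 h, at pH 7.4, tested at 100 uM (a lower number here means that the compound crosses the layer more slowly, a higher number that the compound crosses the layer faster), a test of how quickly a compound passes through an artificial layer. Compound 1 and compound 3 lie within the usual scatter of each other, so the data do not separate them. Compound 2 lies lower than compound 1, and that gap is beyond the scatter.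

The next compound to be measured is compound 4 `Cc1nc2cc(-c3cccc(OCc4ccccc4)c3)nn2c(N2CCC(C)(C)CC2)c1C(OC(C)(C)C)C(=O)O`, which keeps the shared core of compound 1 and changes it in one place: benzyloxy in place of hydrogen on an aromatic carbon. In words, benzyloxy stands in place of hydrogen on an aromatic carbon, meta to a large group.

Among the measured compounds shown here, no two measured compounds differ in just one place, so no measured step can guide the estimate. For the measured compounds named here, the only hint is compound 2, which also carries a benzyloxy group and gives 313 nm/s, although it differs from compound 1 elsewhere too. A small fall in this assay is therefore expected, possibly none beyond the scatter (estimated step: a 1.6-fold lower number from compound 1 to compound 4 (0.19 log units; within the scatter)). The estimated value for compound 4 is 450 nm/s, with an expected range from 200 nm/s to 900 nm/s.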

Compound 4, apparent permeability: 375 nm/s
Compound 4: the middle estimate sits 1.2-fold (0.08 log units) above what was measured; the measured number falls inside the stated range.
By their numbers in this assay, from the lowest: compounds 2, 4, 1 and 3 (each within the scatter of the next, the first and the last beyond it).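

Benzyloxy in place of hydrogen on an aromatic carbon, meta to a large group, gives the first change in this set that can be read on its own in this assay: a 1.9-fold lower number from compound 1 to compound 4 (0.27 log units; within the scatter). The data therefore do not separate the two compounds, so a group of 8 heavy atoms with its own six-membered aromatic ring can stand at this position without a step beyond the scatter, at least on the core of compound 1. Nothing available here gives a measured reason for this result or says what the added group does at this position.

This single step cannot show whether other groups at the same carbon, such as an amine, a carboxylic acid or a longer chain ending in a hydroxyl group, would also stay within the scatter. It also leaves open whether benzyloxy would give a similar number on another carbon of the same ring, or whether a small group such as methoxy would give a step of a different size.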